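Trifluoromethyl in Place of Chloro: Compound 3 Awaits Measurement

The source may hold more compounds than are shown below. What is called first, only, known or untested is meant among the compounds shown, and "the series" means these compounds.

Within the data shown here, compound 1 `O=C(Nc1cccc(-n2cc(-c3ccncc3)c(-c3ccc(Cl)c(O)c3)n2)c1)Nc1ccc(Cl)c(Cl)c1` is one of two compounds measured so far in a functional assay on RPMI-8226 cells (Homo sapiens) for inhibition, read by sulforhodamine B assay, with a stated time of 48 h; on this read-out lower numbers stand for stronger inhibition of growth and higher numbers for weaker inhibition of growth. In this assay compound 1 gives 1030 nM, the lower of the two numbers. Compound 2 `COc1cc(-c2nn(-c3cccc(NC(=O)c4ccc(Cl)c(C(F)(F)F)c4)c3)cc2-c2ccncc2)ccc1Cl` is not a single-change neighbour of compound 1. In this assay compound 2 gives 1620 nM, a gap that lies within the scatter of repeated measurements, so the two compounds cannot be put in order. Compound 3 `O=C(Nc1cccc(-n2cc(-c3ccncc3)c(-c3ccc(Cl)c(O)c3)n2)c1)Nc1ccc(Cl)c(C(F)(F)F)c1` has not yet been measured. It arises from compound 1 by a single change, (trifluoromethyl in place of chloro on an aromatic carbon). Among the measured compounds shown here, no measured pair that differs in only one place is available to show how large such a step has been, so the expected step from compound 1 to compound 3, a 1.3-fold higher number from compound 1 to compound 3 (0.10 log units; within the scatter), is taken as small, within the scatter and of no clear direction. The estimate for compound 3 in this assay is 1300 nM, expected to fall between 500 nM and 3500 nM.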

Compound 3, concentration for 50% growth inhibition: 580 nM
Compound 3: the middle estimate sits 2.2-fold (0.35 log units) above what was measured, and the stated range covers the measured number.
By their numbers in this assay, from the lowest: compounds 3, 1 and 2 (each within the scatter of the next, the first and the last beyond it).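

The series now holds its first pair that differs in only one place: in this assay, trifluoromethyl in place of chloro gives a 1.8-fold lower number from compound 1 to compound 3 (0.25 log units; within the scatter), so this exchange has a measured size here. At this position, on an aromatic carbon ortho to a chloro group and meta to a large group, a group of 4 heavy atoms entering for one of 1 heavy atom leaves the step within the scatter, with no clear direction. Nothing measured here bears on the reason for this result.

As far as these compounds go, whether an amine, a nitrile or a carboxylic acid at this position would give a step beyond the scatter remains open. Also open, from the compounds shown here alone, is whether trifluoromethyl in place of chloro would give a step of similar size on any other compound.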